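Ethyl in place of hydrogen on compound 1

The compounds below may be only part of what the source reports. "The series", "measured", "known", "first", "only" and "open" are said of these compounds alone.

In a functional assay on MT2 cells (Homo sapiens) for cytotoxicity, read by MTT assay (on this read-out higher numbers stand for lower toxicity in this test and lower numbers for higher toxicity in this test), compound 1 `CC(C)=CCOc1cccc(Nc2nccs2)c1` gives 23000 nM and compound 2 `CC(C)=CCOc1cc(Nc2nccs2)ccc1Cl` gives 26000 nM, two values within the scatter of each other. Compound 3 `CCc1ccc(Nc2nccs2)cc1OCC=C(C)C` has ethyl in place of hydrogen on an aromatic carbon of the core of compound 1 (ethyl in place of hydrogen on an aromatic carbon). Among the compounds with values here, the one measured step on that same carbon, chloro in place of hydrogen, is a 1.1-fold higher number from compound 1 to compound 2 (0.05 log units; within the scatter) and shows no change beyond the scatter. Within the data shown here, that single step involves a different group, and no measured step involves ethyl. On this evidence a 1.1-fold higher number from compound 1 to compound 3 (0.04 log units; within the scatter) is the expected step, with nothing beyond the scatter anticipated. Compound 3 is estimated at 25000 nM with 12000 nM to 50000 nM as the expected range.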

Compound 3, half-maximal cytotoxic concentration: 31000 nM
Compound 3: the middle estimate sits 1.2-fold (0.09 log units) below what was measured; the measured number falls inside the stated range.
By their numbers in this assay, from the lowest: compounds 1, 2 and 3 (each within the scatter of the next).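

In this assay ethyl on this carbon, ortho to the (3-methylbut-2-en-1-yl)oxy group, gives a 1.3-fold higher number from compound 1 to compound 3 (0.13 log units; within the scatter) and ethyl in place of chloro gives a 1.2-fold higher number from compound 2 to compound 3 (0.08 log units; within the scatter) within the same scatter. The position now holds hydrogen, chloro and ethyl with no separation among the three compounds, and a carbon substituent shows the same as a halogen did. No measured evidence bears on this result.

From the compounds shown here alone, whether an amine, a carboxylic acid or a longer chain on this carbon would separate from these three remains open. Changes elsewhere on the shared core also remain open.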